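The compounds below may be only part of what the source reports. "The series", "measured", "known", "first", "only" and "open" are said of these compounds alone.

Measured so far:
compound 1 `CCCCC(CC)C(=O)Nc1ccc2ccn(Cc3ccc(C(=O)NS(=O)(=O)c4ccccc4C)cc3OC)c2c1`, in a functional assay (trachea) for antagonist activity, with Cavia porcellus as the target (on this read-out higher numbers stand for higher potency (the scale is a negative logarithm) and lower numbers for lower potency), compound 1 gives 8.9;
compound 2 `COc1cc(C(=O)NS(=O)(=O)c2ccccc2C)ccc1Cn1ccc2ccc(NC(=O)CC3CCCC3)cc21`, in this assay compound 2 gives 9.9.

Compound 1 stands lowest of the two; the only step shown, a number 1.00 log units higher from compound 1 to compound 2 (beyond the scatter), changes the amide side chain and leaves the sulfonyl aryl untouched. Compound 3 `CCCCC(CC)C(=O)Nc1ccc2ccn(Cc3ccc(C(=O)NS(=O)(=O)c4ccc([N+](=O)[O-])cc4)cc3OC)c2c1` differs from compound 1 by 4-nitrophenyl in place of 2-methylphenyl on a sulfonyl sulfur. Among the compounds with values here, no measured step bears on this change, so the expectation rests on compound 1 alone and is set to no step beyond the scatter, no change at the digits printed from compound 1 to compound 3 (within the scatter). Compound 3 is expected at 8.9, with a range of 8.2 to 9.6.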

Compound 3, negative logarithm of the antagonist equilibrium constant: 7.7
Compound 3: middle estimate off by 1.20 log units, on the high side; the measured number lies below the stated range.
By their numbers in this assay, from the lowest: compound 3; then compound 1; then compound 2.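

The aryl on the sulfonyl sulfur is not a silent position: in this assay, 4-nitrophenyl in place of 2-methylphenyl gives a number 1.20 log units lower from compound 1 to compound 3 (beyond the scatter), a step of similar size to the one seen earlier at the amide side chain. Nothing at hand accounts for this drop.

The step changes both the substituent and its printed position, so 4-methylphenyl, 2-nitrophenyl or plain phenyl would be needed to separate the two. As far as these compounds go, whether the step holds with the cyclopentylmethyl side chain of compound 2 also remains open.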